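The source may hold more compounds than are shown below. What is called first, only, known or untested is meant among the compounds shown, and "the series" means these compounds.

In a functional assay (plasma) for inhibition, with Homo sapiens as the target (on this read-out higher numbers stand for weaker inhibition and lower numbers for stronger inhibition), compound 1 `O=C(O)CCC/C=C\C[C@H]1/C(=N/OC(c2ccccc2)c2ccccc2)CC[C@@H]1NS(=O)(=O)c1ccc(Cl)cc1` gives 17000 nM. This is the higher of the two numbers available, so it marks the weaker inhibition. Compound 2 `O=C(O)CCC/C=C\C[C@@H]1[C@@H](NS(=O)(=O)c2ccc(F)cc2)CC[C@@H]1O` gives 640 nM, a number lower by more than the usual scatter of repeat measurements. Within the data shown here, no measured pair here differs in one place only, so the data do not directly show what a single exchange does.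

Compound 3 `O=C(O)CCC/C=C\C[C@H]1/C(=N/OC(c2ccccc2)c2ccccc2)CC[C@@H]1NS(=O)(=O)c1ccc(F)cc1` is compound 1 with one change, fluoro in place of chloro on an aromatic carbon, para to a large group. With only this one atom exchanged, compound 3 is expected to stay close to compound 1 at 17000 nM. The estimated step of a 1.1-fold lower number from compound 1 to compound 3 (0.05 log units; within the scatter) is small, within the scatter, and has no firm direction. Compound 3 is expected at 15000 nM, with a likely range of 5000 nM to 45000 nM.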

Compound 3, half-maximal inhibitory concentration: 17000 nM
For compound 3 the middle estimate is 1.1-fold (0.05 log units) below the measured one; the range from low to high includes it.
By their numbers in this assay, from the lowest: compound 2; then compounds 1 and 3 (each within the scatter of the next).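

In this assay, fluoro in place of chloro on an aromatic carbon, para to a large group, gives no change at the digits printed from compound 1 to compound 3 (within the scatter). This is the only pair shown that differs in one place, so it gives the first direct reading of a single exchange: at this position, the read-out does not tell the two halogens apart, at least on the core of compound 1. Nothing available explains this result.

As far as these compounds go, whether a methoxy group, an amine or a carboxylic acid on that same aromatic carbon would give a different number remains open. From the compounds shown here alone, it is also open what the exchange between chloro and fluoro would do on the core of compound 2.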